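Tetrazole for Carboxylic Acid on a Ring-Bearing Chain

The source may hold more compounds than are shown below. What is called first, only, known or untested is meant among the compounds shown, and "the series" means these compounds.

Measured so far:
Compound 1 `CC(CCc1nnn[nH]1)Cc1ccc(OCc2ccc3ccccc3n2)cc1`, 12 nM in an assay on membranes from lung (Cavia porcellus) for binding affinity to cysteinyl leukotriene receptor (Homo sapiens); on this read-out lower numbers stand for stronger inhibition and higher numbers for weaker inhibition
Compound 2 `CC(CCC(=O)O)Cc1ccc(OCc2ccc3ccccc3n2)cc1`, 43 nM
Compound 3 `O=C(O)CC1(CCc2ccc(OCc3ccc4ccccc4n3)cc2)CCCC1`, 51 nM

Compound 1 and compound 2 differ by 1H-tetrazol-5-yl in place of carboxy on a saturated chain carbon, four bonds along the chain from an aromatic carbon, and that change gave a 3.6-fold lower number from compound 2 to compound 1 (0.55 log units; beyond the scatter). Compound 3 shares the quinolinylmethoxy-phenyl part of compound 2, but the difference between the two cores is not broken down here; their values lie within the scatter of each other. The unmeasured compound 4 `c1ccc2nc(COc3ccc(CCC4(Cc5nnn[nH]5)CCCC4)cc3)ccc2c1` arises from compound 3 by 1H-tetrazol-5-yl in place of carboxy on a saturated chain carbon bound to a saturated ring carbon. This is the same kind of change as that from compound 2 to compound 1, but not the same: the carbon carrying the group is bound to a saturated ring carbon rather than lying four bonds along the chain from an aromatic carbon. Because a 3.6-fold lower number from compound 2 to compound 1 (0.55 log units; beyond the scatter), a step of similar size is expected from compound 3 to compound 4, namely a 3.6-fold lower number from compound 3 to compound 4 (0.56 log units; beyond the scatter). Compound 4 is therefore estimated at 14 nM, roughly between 6 nM and 35 nM.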

Compound 4, inhibition constant: 25 nM
For compound 4 the middle estimate is 1.8-fold (0.25 log units) below the measured one; low and high end bracket the measured number.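

In this assay, 1H-tetrazol-5-yl in place of carboxy on the second core gave a 2.0-fold lower number from compound 3 to compound 4 (0.31 log units; beyond the scatter), in the same direction as a 3.6-fold lower number from compound 2 to compound 1 (0.55 log units; beyond the scatter). The two steps cannot be told apart in size: the same change on two cores in this assay, a 3.6-fold lower number (0.55 log units; beyond the scatter) from compound 2 to compound 1 and a 2.0-fold lower number (0.31 log units; beyond the scatter) from compound 3 to compound 4, 1.8-fold (0.24 log units) apart, within the scatter of two such steps. The change therefore carried over from one core to the other with the same direction, but two pairs show only that and do not establish that it would hold on any further core, nor do they explain the gain.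

The compounds shown leave open whether an amide or a sulfonamide in place of carboxy would behave alike. They also leave open how a longer chain carrying the 1H-tetrazol-5-yl would fare.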